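This account rests on a few compounds, and the source may have more. Where it says the series, first, only, none or still open, it means among the compounds named here.

Two compounds share one core and differ only in the group attached to a saturated chain carbon bound to an amine nitrogen in a ring. Compound 1 `COCCCN1CC2C(C1)C2NC(=O)c1nc(C(C)C)n2ccccc12` carries a 2-methoxyethyl group at that place. In a functional assay on CHO cells for agonist activity at 5-hydroxytryptamine receptor 4 (Homo sapiens), read by a luciferase reporter and cAMP accumulation, with a stated time of 4 h (a lower number here means that less compound is needed, a higher number that more compound is needed for the effect), compound 1 gives > 10000 nM, which is a limit of the assay rather than a number. Compound 2 `CC(C)c1nc(C(=O)NC2C3CN(CC(C)(C)O)CC32)c2ccccn12` carries 1-hydroxy-1-methylethyl in the same place. In this assay compound 2 gives > 10000 nM, again a limit and not a number. The step that the two limits leave unreadable from compound 1 to compound 2 cannot be read, since both values sit at the limit of > 10000 nM in this assay, at which 2 of the 2 values shown sit. Compound 3 `CC(C)c1nc(C(=O)NC2C3CN(CC4CCOCC4)CC32)c2ccccn12` has not yet been measured; it differs from compound 2 by oxan-4-yl in place of 1-hydroxy-1-methylethyl on a saturated chain carbon bound to an amine nitrogen in a ring. Within the data shown here, no measured step resembles this change, and the single step available is unreadable; a direction beyond the scatter cannot be claimed. Compound 3 is therefore expected to stay weak, with an estimated 10000 nM lying between 2000 nM and 50000 nM, which means an expected step of a number no higher from compound 2 to compound 3 (the limit leaves the size open).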

Compound 3, half-maximal effective concentration: 1060 nM
Estimate against measurement, compound 3: 9.4-fold (0.97 log units) above; the whole stated range lies above it.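

Among these compounds, compound 3 is the first compound here to give a readable number in this assay, which shows that the group on a saturated chain carbon bound to an amine nitrogen in a ring can change the result. Oxan-4-yl in place of 1-hydroxy-1-methylethyl gives an at least 9.4-fold lower number from compound 2 to compound 3 (0.97 log units; beyond the scatter), and oxan-4-yl in place of 2-methoxyethyl gives an at least 9.4-fold lower number from compound 1 to compound 3 (0.97 log units; beyond the scatter). Both steps give only a minimum size, and compound 1 and compound 2 each sit at a limit of the assay: the limit of > 10000 nM in this assay, at which 2 of the 3 values shown sit.

As far as these compounds go, it remains open whether the oxygen of the oxan-4-yl ring matters or the ring alone is enough, and a comparison with cyclohexyl, its all-carbon counterpart, would be needed to tell. From the compounds shown here alone, how an amine in the same ring, as in piperidin-4-yl, would read also stays unknown.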